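Oxime versus ketone thioethers on a methylxanthine core

A few compounds are considered here, and "the series" means these few. Any claim that something is new, unique, unknown or untested is made for them only; others in the source may bear on it.

Measured so far in a functional assay on PANC-1 cells (Homo sapiens) for inhibition, read by MTT assay, with a stated time of 48 h; on this read-out lower numbers stand for stronger inhibition and higher numbers for weaker inhibition:

Compound 1 `COc1ccc(C(=O)CSc2nc3[nH]c(=O)n(C)c(=O)c3[nH]2)cc1` gives 5500 nM.
Compound 2 `Cn1c(=O)[nH]c2nc(SCC(=O)c3ccc(Cl)cc3)[nH]c2c1=O` gives 6100 nM.
Compound 3 `COc1ccc(/C(CSc2nc3c([nH]2)c(=O)n(C)c(=O)n3C)=N\O)cc1` gives 910 nM.

Compound 1 and compound 2 share a core and differ only at the aryl ring, by chloro in place of methoxy on an aromatic carbon; this change gives a 1.1-fold higher number from compound 1 to compound 2 (0.04 log units; within the scatter). Compound 3 carries a different core; the difference between the two cores is not broken down here. Its value stands beyond the scatter from both compound 1 and compound 2, so compound 3 is the most potent of the three.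

Compound 4 `Cn1c(=O)c2[nH]c(SC/C(=N/O)c3ccc(Cl)cc3)nc2n(C)c1=O` differs from compound 3 by chloro in place of methoxy on an aromatic carbon, the same change as from compound 1 to compound 2. Because a 1.1-fold higher number from compound 1 to compound 2 (0.04 log units; within the scatter) stayed within the scatter, a similarly small step is expected, a 1.1-fold higher number from compound 3 to compound 4 (0.04 log units; within the scatter). Compound 4 is therefore estimated at 1000 nM in this assay, plausibly between 500 nM and 2200 nM.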

Compound 4, half-maximal inhibitory concentration: 1300 nM
Estimate against measurement, compound 4: 1.3-fold (0.11 log units) below, within the range that was stated.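

In this assay, chloro in place of methoxy on the aromatic ring gives a 1.4-fold higher number from compound 3 to compound 4 (0.15 log units; within the scatter) on the core of compound 3, so this swap leaves the number within the scatter on that core too. Among the compounds shown here, this shows only that the two groups are not told apart on these two cores; it does not show that the swap would stay silent on a further core, nor that other groups at this place would behave alike. The two steps do not differ in size across the cores: the same change on two cores in this assay, a 1.1-fold higher number (0.04 log units; within the scatter) from compound 1 to compound 2 and a 1.4-fold higher number (0.15 log units; within the scatter) from compound 3 to compound 4, 1.3-fold (0.11 log units) apart, within the scatter of two such steps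

Open, on these data alone, is whether an amine or a carboxylic acid in place of chloro or methoxy on this ring would shift the number beyond the scatter. Also open, as far as these compounds go, is what a longer chain in place of the thioether link would do, and how much of the gap to compound 1 belongs to the oxime alone, since the ketones and oximes shown sit on different cores.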